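Octylsulfonamido benzoic acids: aryl replacement toward compound 3

The compounds below may be only part of what the source reports. "The series", "measured", "known", "first", "only" and "open" are said of these compounds alone.

Compound 2 `CCCCCCCCS(=O)(=O)Nc1cc(-c2ccccc2F)ccc1C(=O)O` gives 47200 nM in an assay on mitochondria (strain BALB/c) for inhibition of glycerol-3-phosphate acyltransferase 1, mitochondrial (Mus musculus), read by scintillation counting, with a stated time of 10 min (on this read-out lower numbers stand for stronger inhibition and higher numbers for weaker inhibition), the highest of the two numbers measured, with compound 1 `CCCCCCCCS(=O)(=O)Nc1cc(-c2ccc(CCCC)cc2)ccc1C(=O)O` nearest at 15700 nM. Compound 3 `CCCCCCCCS(=O)(=O)Nc1cc(-c2ccc(O)cc2)ccc1C(=O)O` is not yet measured; it differs from compound 2 by 4-hydroxyphenyl in place of 2-fluorophenyl on an aromatic carbon. For the measured compounds named here, the only step that bears on this change is a 3.0-fold higher number from compound 1 to compound 2 (0.48 log units; beyond the scatter), which exchanged the same aryl group and moved the number modestly. Going by the values given here, no measured step shows a hydroxyl on this ring, so a small move is expected for compound 3, estimated as a 1.6-fold lower number from compound 2 to compound 3 (0.20 log units; within the scatter). Compound 3 is thus expected at 30000 nM, within 10000 nM to 100000 nM.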

Compound 3, half-maximal inhibitory concentration: 64800 nM
Compound 3: the middle estimate sits 2.2-fold (0.33 log units) below what was measured; the range from low to high includes it.
By their numbers in this assay, from the lowest: compound 1; then compounds 2 and 3 (each within the scatter of the next).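

Across 2-fluorophenyl and 4-hydroxyphenyl, the step in this assay is a 1.4-fold higher number from compound 2 to compound 3 (0.14 log units; within the scatter), so these two aryl groups cannot be told apart at this place on the shared core. For the compounds shown here, the exchange of butyl for hydroxy at the same ring position gives a 4.1-fold higher number from compound 1 to compound 3 (0.62 log units; beyond the scatter), which leaves 4-butylphenyl as the only group here with a number set apart from both others. No measurement on hand accounts for either step. Going by these compounds, whether 4-hexylphenyl, with a longer chain, lowers the number further remains open, as does the effect of an amine, as in 4-aminophenyl.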